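A few compounds are considered here, and "the series" means these few. Any claim that something is new, unique, unknown or untested is made for them only; others in the source may bear on it.

Three compounds sharing one core and differing only in the group on an amide-type nitrogen have been measured: compound 1 (`CN(C)C(=O)c1cc2cnc(Nc3ccc(NC(=O)C4(C(=O)Nc5ccc(F)cc5)CC4)cc3)nc2n1C1CCCC1`), compound 2 (`Cc1cccc(NC(=O)C2(C(=O)Nc3ccc(Nc4ncc5cc(C(=O)N(C)C)n(C6CCCC6)c5n4)cc3)CC2)c1`) and compound 3 (`CN(C)C(=O)c1cc2cnc(Nc3ccc(NC(=O)C4(C(=O)Nc5ccc(O)cc5)CC4)cc3)nc2n1C1CCCC1`). In a functional assay on T47D cells (Homo sapiens) for inhibition, read by CCK-8 assay, with a stated time of 72 h, tested at 1 uM (a higher number here means more inhibition of growth at the concentration tested, a lower number less inhibition of growth), compound 3 stands highest of the three at 91.5% and lies clear of compound 1 at 74.7% and compound 2 at 45.7% by margins beyond the usual scatter.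

Compound 4 (`CN(C)C(=O)c1cc2cnc(Nc3ccc(NC(=O)C4(C(=O)Nc5ccccc5)CC4)cc3)nc2n1C1CCCC1`) departs from compound 3 at a single place (hydrogen in place of hydroxy on an aromatic carbon), with hydrogen in place of hydroxy on an aromatic carbon, para to a large group, so that 4-hydroxyphenyl becomes phenyl. Among the measured compounds shown here, no measured compound carries that plain phenyl. The closest evidence is hydroxy in place of fluoro on the same ring, which gave a number 16.8 percentage points higher from compound 1 to compound 3 (beyond the scatter) and is a modest step. Two wider steps also bear on it: 4-hydroxyphenyl in place of 3-methylphenyl gave a number 45.8 percentage points higher from compound 2 to compound 3 (beyond the scatter) and 3-methylphenyl in place of 4-fluorophenyl gave a number 29 percentage points lower from compound 1 to compound 2 (beyond the scatter) and both show that this ring can move the number considerably. Losing the hydroxy should therefore cost about as much as the modest step, or somewhat more. The expected step is a number 21.5 percentage points lower from compound 3 to compound 4 (beyond the scatter) and it is estimated to be a fall. Compound 4 is expected in this assay at 70% (estimated range 50% to 87%).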

Compound 4, percent growth inhibition at one concentration: 52.8%
Estimate against measurement, compound 4: 17.2 percentage points above; the range from low to high includes it.
By their numbers in this assay, from the lowest: compounds 2 and 4 (each within the scatter of the next); then compound 1; then compound 3.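

In this assay, the step of a number 38.7 percentage points lower from compound 3 to compound 4 (beyond the scatter) is large, so the hydroxy on this aromatic carbon accounts for much of the high number of compound 3. The step of a number 21.9 percentage points lower from compound 1 to compound 4 (beyond the scatter) is modest, which shows that fluoro also holds the number clear of plain phenyl, though by less than hydroxy does, and that hydrogen is the poorest of the three on this carbon. Compound 2 goes against any reading that a substituent of any kind on the ring helps: the step of a number 7.1 percentage points higher from compound 2 to compound 4 (within the scatter) puts its 3-methylphenyl level with plain phenyl, so the gain is tied to particular groups and not to substitution as such, and nothing shown explains why hydroxy counts for so much here.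

The compounds shown leave open whether methoxy, an amine or a carboxylic acid on the same carbon would hold the number near that of compound 3 or fall back towards compound 4. They also leave open whether methyl in the place of the hydroxy would behave as the 3-methylphenyl does, since no other ring position is tested with hydroxy or fluoro, and a reading at a single concentration cannot show how far these differences would persist across a range of concentrations.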